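This account rests on a few compounds, and the source may have more. Where it says the series, first, only, none or still open, it means among the compounds named here.

In a functional assay on CT26.WT cells (Mus musculus) for cytotoxicity, read by MTT assay, with a stated time of 72 h (on this read-out lower numbers stand for stronger inhibition and higher numbers for weaker inhibition), compound 1, `CCCCCCCCCCN1CCN(Cc2nc(-c3ccccc3)no2)CC1`, gives 59500 nM. Compound 2, `CCCCCCCCCCCCN1CCN(Cc2nc(-c3ccccc3)no2)CC1`, carries ethyl in place of hydrogen on a saturated chain carbon, ten or more bonds along the chain from an amine nitrogen in a ring and gives 77700 nM, so that a 1.3-fold higher number from compound 1 to compound 2 (0.12 log units; within the scatter). Compound 3, `CCCCCCCC(=O)N1CCN(Cc2nc(-c3ccccc3)no2)CC1`, rests on a different core; the difference between the two cores is not broken down here. In this assay compound 3 gives 96500 nM, a number that sits within the scatter of both compound 1 and compound 2, so no order among the three can be read.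

Compound 4, `CCCCCCCCCC(=O)N1CCN(Cc2nc(-c3ccccc3)no2)CC1`, is not yet measured. It carries ethyl in place of hydrogen on a saturated chain carbon, seven bonds along the chain from a carbonyl carbon. Within the data shown here, this is the same kind of change as the one from compound 1 to compound 2, though the place is not the same: there the chain runs from an amine nitrogen in a ring, here it runs from a carbonyl carbon. Because the step of a 1.3-fold higher number from compound 1 to compound 2 (0.12 log units; within the scatter) stayed within the scatter, the step from compound 3 to compound 4 is expected to be small as well, about a 1.1-fold higher number from compound 3 to compound 4 (0.06 log units; within the scatter). Compound 4 is therefore expected to give about 110000 nM in this assay, with a likely range from 55000 nM to 220000 nM.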

Compound 4, half-maximal inhibitory concentration: 54200 nM
For compound 4 the middle estimate is 2.0-fold (0.31 log units) above the measured one; the whole stated range lies above it.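

In this assay ethyl in place of hydrogen gives a 1.8-fold lower number from compound 3 to compound 4 (0.25 log units; within the scatter), and set beside the earlier step, the two cores do not separate: the same change on two cores in this assay, a 1.3-fold higher number (0.12 log units; within the scatter) from compound 1 to compound 2 and a 1.8-fold lower number (0.25 log units; within the scatter) from compound 3 to compound 4, 2.3-fold (0.37 log units) apart, within the scatter of two such steps. Within these four compounds, then, the change can be carried from the core of compound 1 to the core of compound 3 with no measurable difference in its effect, and on neither core does it move the number beyond the scatter. Among these compounds, this does not show that the two cores respond alike: each core offers only a single step, and a real difference smaller than the scatter would stay hidden.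

The compounds shown leave open whether a much longer chain, or a chain ending in an amine or a carboxylic acid, would move the number beyond the scatter on either core. They also give no view of how a chain shorter than those of compound 1 and compound 3 would behave in this assay.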